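Further Sulfation of Compound 2 and Its Expected Binding

The compounds below may be only part of what the source reports. "The series", "measured", "known", "first", "only" and "open" are said of these compounds alone.

Compound 2, `CC(=O)N[C@H]1[C@@H](OC[C@@H](O)[C@@H](O)[C@H](O)[C@@H](O)CNc2cccc(NC(=O)CCCCC3CCSS3)c2)O[C@H](CO)[C@H](OS(=O)(=O)O)[C@@H]1O[C@@H]1O[C@H](C(=O)O)[C@@H](O)[C@H](OS(=O)(=O)O)[C@H]1O`, has been measured in an assay on isolated protein for binding affinity to fibroblast growth factor 2 (Homo sapiens), read by surface plasmon resonance (a higher number here means weaker binding, a lower number tighter binding), where compound 2 gives 41 nM. Among the measured compounds shown here, its only measured relative is compound 1, `CC(=O)N[C@H]1[C@@H](OC[C@@H](O)[C@@H](O)[C@H](O)[C@@H](O)CNc2cccc(NC(=O)CCCCC3CCSS3)c2)O[C@H](CO)[C@H](O)[C@@H]1O[C@@H]1O[C@H](C(=O)O)[C@@H](O)[C@H](OS(=O)(=O)O)[C@H]1O`, which in this assay gives 25 nM. The step between them, a 1.6-fold higher number from compound 1 to compound 2 (0.21 log units; within the scatter), lies within the scatter, so the two numbers stand together and neither compound can be set apart from the other on this evidence. Compound 3, `CC(=O)N[C@H]1[C@@H](OC[C@@H](O)[C@@H](O)[C@H](O)[C@@H](O)CNc2cccc(NC(=O)CCCCC3CCSS3)c2)O[C@H](COS(=O)(=O)O)[C@H](OS(=O)(=O)O)[C@@H]1O[C@@H]1O[C@H](C(=O)O)[C@@H](O)[C@H](OS(=O)(=O)O)[C@H]1O`, has not yet been measured. It differs from compound 2 in a single place: sulfo in place of hydrogen on an oxygen on a saturated carbon. For the measured compounds named here, the one measured step that bears on this change is a 1.6-fold higher number from compound 1 to compound 2 (0.21 log units; within the scatter), the same kind of addition made on another oxygen of the shared core, and it moved the number only within the scatter. On that basis compound 3 is expected to shift by a 1.2-fold higher number from compound 2 to compound 3 (0.09 log units; within the scatter), a step that would not be beyond the scatter. Compound 3 is accordingly estimated at 50 nM in this assay, with a range from 20 nM to 130 nM.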

Compound 3, dissociation constant: 60 nM
The estimate for compound 3 lay 1.2-fold (0.08 log units) below the measured number; low and high end bracket the measured number.
By their numbers in this assay, from the lowest: compounds 1, 2 and 3 (each within the scatter of the next, the first and the last beyond it).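

In this assay, the change from hydroxymethyl to (sulfooxy)methyl gives a 1.5-fold higher number from compound 2 to compound 3 (0.17 log units; within the scatter) and so places a sulfo group on an oxygen on a saturated carbon without a step that can be told from the scatter. Until now only one such addition, on another oxygen of the shared core, could be read, as a 1.6-fold higher number from compound 1 to compound 2 (0.21 log units; within the scatter); the second step shows that the same replacement at this further oxygen also stays within the scatter, so the two single steps agree in that respect. Nothing given here bears on why either step is so small.

What the compounds leave open is whether the sulfo group matters at this position at all in its own right, since a phosphate, a carboxylic acid or a methyl ether on the same oxygen lies outside the set, and a comparison with any of them would be needed to tell whether the oxygen accepts other groups equally. Also open, going by these compounds, is how far the number would move with an amine or a longer chain at the hydroxymethyl carbon, or with sulfo groups on the hydroxy groups of the shared core that still carry hydrogen.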